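Replacing a cyclopentyl amide with an anisoyl amide

This account rests on a few compounds, and the source may have more. Where it says the series, first, only, none or still open, it means among the compounds named here.

Compound 1 `Cc1cccc(Cn2c(CN3CCN(C(=O)C4CCCC4)CC3)nc3ccccc32)c1` and compound 2 `CC(C)CCn1c(CN2CCN(C(=O)C3CC3)CC2)nc2ccccc21` share the same core and differ in two places, so no single step can be read between them. In an assay on isolated protein for inhibition of aldehyde dehydrogenase 1A1 (Homo sapiens), read by spectrophotometry, tested at 10 uM (a lower number here means less inhibition, a higher number more inhibition at the concentration tested (going by the name of the read-out)), compound 1 gives 67.5%, and in this assay compound 2 gives 70%; the two numbers lie within the scatter of each other, so neither can be called the stronger. Compound 1 is the lower of the two numbers shown. Compound 3 `COc1ccc(C(=O)N2CCN(Cc3nc4ccccc4n3Cc3cccc(C)c3)CC2)cc1` is built from compound 1 by one change, (4-methoxyphenyl in place of cyclopentyl on a carbonyl carbon). Nothing measured here tells how such a change on the carbonyl carbon affects this read-out, so the step of a number 2.5 percentage points lower from compound 1 to compound 3 (within the scatter) is expected to be small and possibly none beyond the scatter, resting only on compound 1 at 67.5%. Compound 3 is therefore estimated to give 65% in this assay, with a range from 40% to 85%.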

Compound 3, a percentage reported as inhibition, at one concentration (the size of the read-out at that concentration, not a potency): 55.5%
Compound 3: the middle estimate sits 9.5 percentage points above what was measured; the measured number falls inside the stated range.
By their numbers in this assay, from the lowest: compound 3; then compounds 1 and 2 (each within the scatter of the next).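

Putting 4-methoxyphenyl in place of cyclopentyl on a carbonyl carbon gives a number 12 percentage points lower from compound 1 to compound 3 (beyond the scatter) in this assay. Going by these compounds alone, this is the only comparison here that isolates one place, and it shows that the read-out responds to the group on this carbonyl carbon, although inhibition is reduced rather than lost: compound 3 still gives 55.5% at the concentration tested. Nothing available accounts for the lower number.

The single change swaps a non-aromatic ring for an aromatic one and also brings in the methoxy group, so the compounds shown leave open which of these goes with the step. A plain phenyl or a 4-hydroxyphenyl on the same carbonyl carbon would separate the two, and a tert-butyl would test a group with no ring at all.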